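Side-chain change from compound 2 to compound 4

The compounds below may be only part of what the source reports. "The series", "measured", "known", "first", "only" and "open" are said of these compounds alone.

In an ADME assay on microsomes from liver (Canis lupus familiaris) for metabolic stability, read by LC-MS, tested at 1 uM (a lower number here means slower removal, a higher number faster removal of the compound), compound 2 `c1cc([C@H]2CC[C@]3(CC2)OOC2(O3)C3CC4CC(C3)CC2C4)ccc1OCCC1CCNCC1` gives 16 mL.min-1.g-1 and compound 1 `NC(=O)C1CCN(Cc2ccc([C@H]3CC[C@]4(CC3)OOC3(O4)C4CC5CC(C4)CC3C5)cc2)CC1` gives 10 mL.min-1.g-1 with a 1.6-fold higher number from compound 1 to compound 2 (0.20 log units; within the scatter) between them. Compound 3 `N[C@H]1CC[C@@H](Oc2ccc([C@H]3CC[C@]4(CC3)OOC3(O4)C4CC5CC(C4)CC3C5)cc2)CC1` gives < 7 mL.min-1.g-1 as a limit of the assay only. Within the data shown here, the move to that limit reads an at least 2.2-fold lower number from compound 2 to compound 3 (0.35 log units; beyond the scatter) and is the one measured step that clears the scatter, whereas an at least 1.4-fold lower number from compound 1 to compound 3 (0.15 log units; that floor lies within the scatter) does not. Compound 4 `CC1(C)CC(O)(COc2ccc([C@H]3CC[C@]4(CC3)OOC3(O4)C4CC5CC(C4)CC3C5)cc2)CC(C)(C)N1` follows from compound 2 by 4-hydroxy-2,2,6,6-tetramethylpiperidin-4-yl in place of (piperidin-4-yl)methyl on a saturated chain carbon bound to an oxygen on an aromatic ring on a saturated chain carbon bound to an oxygen on an aromatic ring. In this assay a small fall is expected but no step beyond the scatter, and the estimated change is a 1.3-fold lower number from compound 2 to compound 4 (0.12 log units; within the scatter) in all. For compound 4 the estimated value is 12 mL.min-1.g-1 with an expected range from 7 mL.min-1.g-1 to 22 mL.min-1.g-1 in this measurement.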

Compound 4, intrinsic clearance in microsomes: < 7 mL.min-1.g-1
Compound 4 gave a limit, no number; the forecaster's own chance of this, stated with the estimate: 20%; at least 1.7-fold (0.23 log units) between middle value and limit.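

In this assay the 4-hydroxy-2,2,6,6-tetramethylpiperidin-4-yl group, on a saturated chain carbon bound to an oxygen on an aromatic ring, gives an at least 2.2-fold lower number from compound 2 to compound 4 (0.35 log units; beyond the scatter), so a second change from the side chain of compound 2 now clears the scatter. Compound 4 reads only as a limit of the assay. Compound 3 and compound 4 cannot be ordered, and the step between them cannot be read: the limit of < 7 mL.min-1.g-1 in this assay, at which 2 of the 4 values shown sit.

Whether the hydroxy group or the tetramethyl substitution accounts for the step stays open. A 4-hydroxypiperidin-4-yl group on the same chain would separate the two.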